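The compounds below may be only part of what the source reports. "The series", "measured", "known", "first", "only" and "open" are said of these compounds alone.

Within the data shown here, in a functional assay on MIA PaCa-2 cells (Homo sapiens) for inhibition, read by MTT assay, with a stated time of 3 days (on this read-out higher numbers stand for weaker inhibition and lower numbers for stronger inhibition), compound 1 (`CCN(CC)S(=O)(=O)c1ccc(S(=O)(=O)N2CCC[C@@H](C(=O)N[C@@H]3CCN(C(=O)OC(C)(C)C)C3)C2)cc1`) gives 500 nM as its result, and compound 2 (`CCN(CC)S(=O)(=O)c1ccc(S(=O)(=O)N2CCC[C@@H](C(=O)NC3CN(C(=O)C4CC4)C3)C2)cc1`) gives 3100 nM as the higher of the two numbers so far, which means the weaker inhibition. Compound 3 (`CCN1CC(NC(=O)[C@@H]2CCCN(S(=O)(=O)c3ccc(S(=O)(=O)N(CC)CC)cc3)C2)C1`) is the next one to be tested. It differs from compound 2 in one place: ethyl in place of cyclopropylcarbonyl on an amine nitrogen in a ring and so carries ethyl in place of cyclopropylcarbonyl on an amine nitrogen in a ring. Among the measured compounds shown here, only one measured step bears on this place: a 6.2-fold higher number from compound 1 to compound 2 (0.79 log units; beyond the scatter) came with a change both of the group on that ring nitrogen and of the ring itself. That step was modest, yet beyond the scatter. For the measured compounds named here, compound 1 and compound 2 both hold a carbonyl on that nitrogen while compound 3 holds none, so no measured pair tests this change directly. A modest step toward a higher number is therefore expected in this assay with wide uncertainty. The expected change is a 1.6-fold higher number from compound 2 to compound 3 (0.21 log units; within the scatter) in this estimate. The estimated value for compound 3 is 5000 nM with a likely range from 1300 nM to 20000 nM overall.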

Compound 3, half-maximal inhibitory concentration: > 10000 nM
Compound 3: no number, only a limit; the forecaster's own chance of this, stated with the estimate: 15%; middle value at least 2.0-fold (0.30 log units) away from the limit.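

Compound 3 gives only a limit of the assay, not a number: the limit of > 10000 nM in this assay, at which 1 of the 3 values shown sits. Replacing cyclopropylcarbonyl with ethyl on the amine nitrogen of the four-membered ring changes that nitrogen alone and leaves the ring in place, and it gives an at least 3.2-fold higher number from compound 2 to compound 3 (0.50 log units; beyond the scatter), so the group on this nitrogen matters independently of any change to the ring. Compared with the tert-butoxycarbonyl compound, which differs in both the ring and its nitrogen group, the result is an at least 20-fold higher number from compound 1 to compound 3 (1.30 log units; beyond the scatter), a large step, and among these three compounds the two with a carbonyl on this nitrogen give measured numbers, while the one with ethyl gives only a limit.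

The compounds shown leave open whether the carbonyl or the three-membered ring of the cyclopropylcarbonyl group is what counts, and an acetyl group or a cyclopropylmethyl group on the same nitrogen would separate the two. The true size of the step also remains unknown while compound 3 has only a limit, and no pair shown changes the ring alone.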